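This account rests on a few compounds, and the source may have more. Where it says the series, first, only, none or still open, it means among the compounds named here.

Among the measured compounds shown here, in a functional assay on MCF7 cells (Homo sapiens) for inhibition, read by sulforhodamine B assay (on this read-out higher numbers stand for weaker inhibition of growth and lower numbers for stronger inhibition of growth), compound 2 `Cc1ccc2[nH]c(-c3ccc(-c4ccc(-c5ccccc5)cc4)cc3)nc2c1` gives 31600 nM, the higher of the two numbers measured so far. Compound 3 `Cc1ccc2[nH]c(-c3ccc(-c4ccc(-c5ccc(OC(F)(F)F)cc5)cc4)cc3)nc2c1` differs from compound 2 by one change, trifluoromethoxy in place of hydrogen on an aromatic carbon, para to a large group. Compound 1 `Oc1cccc2[nH]c(-c3ccc(-c4ccc(-c5ccc(OC(F)(F)F)cc5)cc4)cc3)nc12` also carries trifluoromethoxy on a different core and gives 2210 nM. For the measured compounds named here, that number is lower than the one for compound 2, and the gap between them lies beyond the scatter. On that single comparison, a drop beyond the scatter, towards stronger inhibition of growth, is expected. The estimated step of a 5.3-fold lower number from compound 2 to compound 3 (0.72 log units; beyond the scatter) reflects this. The expected value for compound 3 is 6000 nM, with an estimated range of 1800 nM to 20000 nM.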

Compound 3, concentration for 50% growth inhibition: 31000 nM
The estimate for compound 3 lay 5.2-fold (0.71 log units) below the measured number; the whole stated range lies below it.
By their numbers in this assay, from the lowest: compound 1; then compounds 3 and 2 (each within the scatter of the next).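

In this assay, trifluoromethoxy para to a large group makes no difference beyond the scatter on the core of compound 2: a 1.0-fold lower number from compound 2 to compound 3 (0.01 log units; within the scatter). With trifluoromethoxy held constant, the change of core gives a large step: a 14-fold higher number from compound 1 to compound 3 (1.15 log units; beyond the scatter). The lower number of compound 1 therefore goes with its core, not with trifluoromethoxy. Nothing available explains either step. The compounds shown leave open whether trifluoromethoxy matters on the core of compound 1, and whether an amine or a carboxylic acid at this position would shift the number on the core of compound 2.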